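Replacing the ring hydroxy with a methoxy on the amide

This account rests on a few compounds, and the source may have more. Where it says the series, first, only, none or still open, it means among the compounds named here.

Compound 3 `COc1cc(N(C)CCN(C)C)c(NC(=O)c2ccnc(O)c2)cc1Nc1nccc(-c2cn(C)c3ccccc23)n1` gives 11200 nM in a functional assay on A549 cells (Homo sapiens) for antiproliferative activity, read by MTT assay, with a stated time of 72 h (on this read-out higher numbers stand for weaker inhibition and lower numbers for stronger inhibition), the highest of the three numbers shown. Compound 1 `COc1cc(N(C)CCN(C)C)c(NC(=O)c2ccncc2)cc1Nc1nccc(-c2cn(C)c3ccccc23)n1` gives 10400 nM and compound 2 `COc1cc(N(C)CCN(C)C)c(NC(=O)c2ccnc(Cl)c2)cc1Nc1nccc(-c2cn(C)c3ccccc23)n1` gives 970 nM in this assay; the step of a 1.1-fold higher number from compound 1 to compound 3 (0.03 log units; within the scatter) lies within the scatter, whereas a 12-fold higher number from compound 2 to compound 3 (1.06 log units; beyond the scatter) is large. Compound 4 `COc1cc(N(C)CCN(C)C)c(NC(=O)c2ccncc2OC)cc1Nc1nccc(-c2cn(C)c3ccccc23)n1` carries 3-methoxypyridin-4-yl in place of 2-hydroxypyridin-4-yl on a carbonyl carbon. Going by the values given here, no measured step involves a methoxy group; the nearest guide is a 1.1-fold higher number from compound 1 to compound 3 (0.03 log units; within the scatter), where the hydroxy made no difference beyond the scatter, while an 11-fold lower number from compound 1 to compound 2 (1.03 log units; beyond the scatter) shows that a substituent on this ring can shift the number greatly. Compound 4 is therefore expected to show an estimated step of a 1.4-fold lower number from compound 3 to compound 4 (0.15 log units; within the scatter) that is modest, with its direction uncertain. Compound 4 is estimated at 8000 nM, within 2000 nM to 30000 nM.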

Compound 4, half-maximal inhibitory concentration: 2690 nM
Estimate against measurement, compound 4: 3.0-fold (0.47 log units) above; the range from low to high includes it.
By their numbers in this assay, from the lowest: compound 2; then compound 4; then compounds 1 and 3 (each within the scatter of the next).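

In this assay a second substituent on this ring, the methoxy of the 3-methoxypyridin-4-yl amide, also lowers the number: a 3.9-fold lower number from compound 1 to compound 4 (0.59 log units; beyond the scatter) against the unsubstituted amide and a 4.2-fold lower number from compound 3 to compound 4 (0.62 log units; beyond the scatter) against the hydroxy, so an oxygen-linked group here need not leave the number unchanged. Chloro still gives the lowest number, with a 2.8-fold higher number from compound 2 to compound 4 (0.44 log units; beyond the scatter) on going to the methoxy. Nothing given explains these differences.

As far as these compounds go, whether the gain belongs to the methoxy itself or to its place on the ring stays open, since 2-chloropyridin-4-yl and 2-hydroxypyridin-4-yl are named differently. A 2-methoxypyridin-4-yl or 3-chloropyridin-4-yl amide would separate the two, and how an amine or an ethoxy would fare is also unknown.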